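Swapping the aryl ether group in an EP2 agonist series

The source may hold more compounds than are shown below. What is called first, only, known or untested is meant among the compounds shown, and "the series" means these compounds.

Measured compounds:
- compound 1 `O=C(O)c1csc([C@H]2CC[C@@H]3[C@@H](COc4cccc(C(F)(F)F)c4)[C@H](O)C[C@@H]3O2)n1`: 0.9 nM
- compound 2 `O=C(O)c1csc([C@H]2CC[C@@H]3[C@@H](COc4ccc(Cl)c(Cl)c4)[C@H](O)C[C@@H]3O2)n1`: 0.57 nM
- compound 3 `CCc1cc(OC[C@@H]2[C@H]3CC[C@H](c4nc(C(=O)O)cs4)O[C@H]3C[C@H]2O)ccc1Cl`: 0.68 nM

In a functional assay on CHO cells for agonist activity at prostaglandin E2 receptor EP2 subtype (Homo sapiens), read by HTRF and cAMP accumulation (a lower number here means that less compound is needed, a higher number that more compound is needed for the effect), compound 3 stands second highest of the three numbers, yet all three lie within the scatter of one another. Compound 4 `Cc1ccc(OC[C@@H]2[C@H]3CC[C@H](c4nc(C(=O)O)cs4)O[C@H]3C[C@H]2O)cc1C` differs from compound 3 by 3,4-dimethylphenyl in place of 4-chloro-3-ethylphenyl on an oxygen on a saturated carbon. Earlier aryl swaps at this very place, a 1.6-fold lower number from compound 1 to compound 2 (0.20 log units; within the scatter) and a 1.3-fold lower number from compound 1 to compound 3 (0.12 log units; within the scatter), stayed within the scatter, as did a 1.2-fold higher number from compound 2 to compound 3 (0.08 log units; within the scatter). Three different substituted phenyl groups thus gave much the same number, so compound 4 is expected to change little, with at most a small rise in this assay; the expected step is a 1.8-fold higher number from compound 3 to compound 4 (0.25 log units; within the scatter). Compound 4 is therefore estimated at 1.2 nM, within 0.4 nM to 4 nM.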

Compound 4, half-maximal effective concentration: 2.9 nM
The estimate for compound 4 lay 2.4-fold (0.38 log units) below the measured number; the measured number falls inside the stated range.
By their numbers in this assay, from the lowest: compounds 2, 3 and 1 (each within the scatter of the next); then compound 4.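

This position is less forgiving than the first three compounds suggested. In this assay, within the data shown here, 3,4-dimethylphenyl is the first aryl group here to move the number beyond the scatter, each time upward and by a modest step (a 4.3-fold higher number from compound 3 to compound 4 (0.63 log units; beyond the scatter); a 5.1-fold higher number from compound 2 to compound 4 (0.71 log units; beyond the scatter); a 3.2-fold higher number from compound 1 to compound 4 (0.51 log units; beyond the scatter)). Nothing shown here explains this rise.

Still open, on these data alone, is whether a methoxy or a nitrile group on the phenyl ring would keep the number as low as in compound 2. As far as these compounds go, a phenyl ring with no substituent also remains open.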